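Swapping pyrimidin-5-yl for quinolin-3-yl on compound 2

A few compounds are considered here, and "the series" means these few. Any claim that something is new, unique, unknown or untested is made for them only; others in the source may bear on it.

Measured in a physicochemical assay for solubility, in phosphate buffer, at pH 7.4; on this read-out higher numbers stand for higher solubility and lower numbers for lower solubility
Compound 1 `OC1CCN(c2nccnc2OC2CN(c3ccc4ccccc4n3)C2)CC1` gives 99000 nM here
Compound 2 `c1ccc2nc(N3CC(Oc4nccnc4-c4cncnc4)C3)ccc2c1` gives 254000 nM here

Of these two, compound 2 stands highest, at 254000 nM on this read-out, beyond the scatter. The change to compound 3 `c1ccc2ncc(-c3nccnc3OC3CN(c4ccc5ccccc5n4)C3)cc2c1` is quinolin-3-yl in place of pyrimidin-5-yl on an aromatic carbon on an aromatic carbon next to the ring nitrogen. Among the compounds with values here, only one measured step bears on it: a 2.6-fold higher number from compound 1 to compound 2 (0.41 log units; beyond the scatter) came with pyrimidin-5-yl in place of 4-hydroxypiperidin-1-yl, and it was modest. Compound 3 gives up that pyrimidin-5-yl, and quinolin-3-yl is unmeasured, so a downward step larger than that one is expected in this assay here. The expected step is an 8.5-fold lower number from compound 2 to compound 3 (0.93 log units; beyond the scatter) as estimated. For compound 3 the estimate is 30000 nM with an expected range of 6000 nM to 120000 nM in repeat measurements.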

Compound 3, solubility: < 1000 nM
Compound 3 ended at the assay's limit (the forecaster's own chance of this, stated with the estimate: 5%); middle value at least 30-fold (1.47 log units) from the limit.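

In this assay, compound 3 reads only as a limit, not a number: the limit of < 1000 nM in this assay, at which 1 of the 3 values shown sits.

Putting quinolin-3-yl on this aromatic carbon next to the ring nitrogen brings an at least 250-fold lower number from compound 2 to compound 3 (2.40 log units; beyond the scatter), and against the 4-hydroxypiperidin-1-yl group it brings an at least 99-fold lower number from compound 1 to compound 3 (1.99 log units; beyond the scatter). Both steps are large, so the group at this position can move the read-out much further than the modest earlier step showed.

The compounds shown cannot separate the carbon-only ring that enters from the change in ring nitrogens. Phenyl or a simple amine such as morpholin-4-yl at this position remains an open comparison.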